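Isopropyl for cyanomethyl on compound 2

The source may report more compounds than this note shows. Statements on the series, on what has been measured and on what is new or still open speak of the compounds shown alone.

Measured so far in a physicochemical assay for metabolic stability, in simulated intestinal fluid, with a stated time of 15 min, tested at 4 uM (on this read-out lower numbers stand for a less stable compound and higher numbers for a more stable compound), are these compounds
- compound 1 `COC[C@H](NC(=O)c1cc(C)on1)C(=O)N[C@@H](CC(C)C)C(=O)N[C@@H](CC(C)C)C(=O)[C@@]1(C)CO1` gives 90%
- compound 2 `COC[C@H](NC(=O)c1cc(C)on1)C(=O)N[C@@H](CC#N)C(=O)N[C@@H](CC(C)C)C(=O)[C@@]1(C)CO1` gives 100%

For the measured compounds named here, compound 2 lies within the scatter of compound 1, the only other measured compound. Compound 3 `COC[C@H](NC(=O)c1cc(C)on1)C(=O)N[C@H](C(=O)N[C@@H](CC(C)C)C(=O)[C@@]1(C)CO1)C(C)C` is the next to be read, and its change from its neighbour is isopropyl in place of cyanomethyl on a saturated chain carbon bound to an amide-type nitrogen and a carbonyl carbon with isopropyl in place of cyanomethyl. Going by the values given here, one measured step bears on this, a number 10 percentage points higher from compound 1 to compound 2 (within the scatter) and it falls on a different chain carbon, so it is only a loose guide. The estimated step is a number 8 percentage points lower from compound 2 to compound 3 (within the scatter) and nothing beyond the scatter is expected. For compound 3 the expected value is 92% (estimated range 78% to 100%).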

Compound 3, percent of the compound remaining: 95%
Beside the measured number, compound 3's estimate is 3 percentage points below it; the range from low to high includes it.
By their numbers in this assay, from the lowest: compounds 1, 3 and 2 (each within the scatter of the next).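

With this step, three groups have been read on this saturated chain carbon bound to an amide-type nitrogen and a carbonyl carbon in this assay. Isopropyl in place of cyanomethyl gives (a number 5 percentage points lower from compound 2 to compound 3 (within the scatter)), and isopropyl in place of isobutyl gives (a number 5 percentage points higher from compound 1 to compound 3 (within the scatter)), so isobutyl, cyanomethyl and isopropyl all lie within the scatter of one another here. No supporting measurement bears on this result. Going by these compounds, whether an amine or a carboxylic acid on this carbon would stay within that scatter remains open.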